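Changing the Group on the Carbon Doubly Bonded to Nitrogen

The source may hold more compounds than are shown below. What is called first, only, known or untested is meant among the compounds shown, and "the series" means these compounds.

Three compounds sharing one core were measured in a functional assay on HT-29 cells (Homo sapiens) for cytotoxicity, read by sulforhodamine B assay; a lower number here means a stronger inhibitor of growth, a higher number a weaker inhibitor of growth. Compound 1 `CC1=CC[C@@H]([C@@](C)(O)CCCC(C)(C)NC(=S)N/N=C\c2ccc(C)cc2)CC1` gives 10400 nM. Compound 2 `CC1=CC[C@@H]([C@@](C)(O)CCCC(C)(C)NC(=S)N/N=C\c2ccccc2Cl)CC1` gives 23700 nM, and compound 3 `CC1=CC[C@@H]([C@@](C)(O)CCCC(C)(C)NC(=S)N/N=C\c2cccc(Cl)c2)CC1` gives 6890 nM. Compound 3 carries the lowest number of the three: a 1.5-fold lower number from compound 1 to compound 3 (0.18 log units; within the scatter), a gap within the scatter, while a 3.4-fold lower number from compound 2 to compound 3 (0.54 log units; beyond the scatter), a gap beyond it. Compound 4 `CC1=CC[C@@H]([C@@](C)(O)CCCC(C)(C)NC(=S)N/N=C(/C)c2ccccc2)CC1` differs from compound 3 in that (a group of 9 heavy atoms (8 carbon, 1 nitrogen; one six-membered aromatic ring of carbon only) in place of a group of 9 heavy atoms (7 carbon, 1 nitrogen, 1 chlorine; one six-membered aromatic ring of carbon only), on an amide-type nitrogen). Every step measured so far changed the group on that same carbon with a double bond to nitrogen: a 2.3-fold higher number from compound 1 to compound 2 (0.36 log units; beyond the scatter), a 1.5-fold lower number from compound 1 to compound 3 (0.18 log units; within the scatter) and a 3.4-fold lower number from compound 2 to compound 3 (0.54 log units; beyond the scatter). All of these stayed within a modest span, so a change of this kind has so far moved the number only a little in either direction. None of them removed the chlorine, so the direction for compound 4 is uncertain, and a step no larger than those already seen, quite possibly within the scatter, is expected, namely a 1.4-fold higher number from compound 3 to compound 4 (0.14 log units; within the scatter). Compound 4 is therefore estimated at 9500 nM, with a range from 4000 nM to 22000 nM.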

Compound 4, concentration for 50% growth inhibition: 28400 nM
Estimate against measurement, compound 4: 3.0-fold (0.48 log units) below; the measured number lies above the stated range.
By their numbers in this assay, from the lowest: compounds 3 and 1 (each within the scatter of the next); then compounds 2 and 4 (each within the scatter of the next).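

At this position the number can move beyond the scatter even when the ring-bearing group keeps the same count of heavy atoms: replacing the chlorine-bearing group gives a 4.1-fold higher number from compound 3 to compound 4 (0.62 log units; beyond the scatter). Lacking chlorine does not settle the number on its own, since the chlorine-free group of compound 1 also differs clearly from the new group, with a 2.7-fold higher number from compound 1 to compound 4 (0.44 log units; beyond the scatter), while the chlorine-bearing group of compound 2 does not, with a 1.2-fold higher number from compound 2 to compound 4 (0.08 log units; within the scatter). No measurement here offers an explanation for these steps.

The new group differs from the earlier ones in more than the chlorine, so the part each difference plays cannot be separated. As far as these compounds go, it remains open how a plain phenyl group with only hydrogen on the carbon with a double bond to nitrogen would read, or a ring carrying an amine or a carboxylic acid.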